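Working notes on three anilides and one untested analogue

The source may hold more compounds than are shown below. What is called first, only, known or untested is meant among the compounds shown, and "the series" means these compounds.

Measured in a functional assay on the whole organism (strain Swiss albino) for inhibition, with Mus musculus as the target, in the formalin test, with a stated time of 30 min, at a dose of 100 mg/kg; on this read-out higher numbers stand for more inhibition at the one dose given (going by the name of the read-out) and lower numbers for less inhibition:
compound 1 `CCN1CCc2c(c(C)nn2C(=O)Nc2cc(C)ccc2C)C1` gives 55.8%
compound 2 `CCN1CCc2c(c(C)nn2C(=O)Nc2cccc(C(F)(F)F)c2)C1` gives 23.1%
compound 3 `CCN1CCc2c(c(C(C)(C)C)nn2C(=O)Nc2cc(C)ccc2C)C1` gives 15.7%

Compound 3 differs from compound 1 by tert-butyl in place of methyl on an aromatic carbon; in this assay this gave a number 40.1 percentage points lower from compound 1 to compound 3 (beyond the scatter). Compound 2 carries a different anilide part from compound 1; the difference between the two cores is not broken down here. The numbers for compound 2 and compound 3 lie within the scatter of each other, so nothing is said about their order.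

Compound 4 `CCN1CCc2c(c(C(C)(C)C)nn2C(=O)Nc2cccc(C(F)(F)F)c2)C1` has not been measured. It differs from compound 2 by tert-butyl in place of methyl on an aromatic carbon, at the same place as the change from compound 1 to compound 3, so it is the same change, now made on the core of compound 2.

Since compound 2 already gives 23.1%, which leaves less room for a further drop of the same size, the step from compound 2 to compound 4 is expected to be smaller than the one seen before, a number 13.1 percentage points lower from compound 2 to compound 4 (beyond the scatter). Compound 4 is therefore estimated at 10% in this assay, expected between 0% and 25%.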

Compound 4, a percentage reported as inhibition, in the whole organism at one dose (the size of the read-out at that dose, not a potency): 55.1%
Compound 4: the middle estimate sits 45.1 percentage points below what was measured; measured number outside the range, above it.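

In this assay, tert-butyl in place of methyl on the aromatic carbon gave a number 32 percentage points higher from compound 2 to compound 4 (beyond the scatter), so the effect of this change does not carry from one core to the other in this series, and its direction depends on the anilide part that accompanies it: the same change on two cores in this assay, a number 40.1 percentage points lower (beyond the scatter) from compound 1 to compound 3 and a number 32 percentage points higher (beyond the scatter) from compound 2 to compound 4, 72.1 percentage points apart, beyond the scatter of two such steps

This reversal rests on two matched pairs, read at one dose and at one time, so it shows that a step measured on one core cannot be transferred to the other here, but gives no general rule for other anilides. The anilide parts of compound 1 and compound 2 differ in more than one group, and the data do not show which of those groups accounts for the reversal, nor why it occurs.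

Among the compounds shown here, it remains open whether anilides carrying only one methyl or only one trifluoromethyl group would follow compound 1 or compound 2. As far as these compounds go, it is also open how isopropyl or cyclopropyl on the same aromatic carbon would behave on each core.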